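Stepwise bromination and lipophilicity in the series

This account rests on a few compounds, and the source may have more. Where it says the series, first, only, none or still open, it means among the compounds named here.

Compound 1 `CC#CCn1c(N2CCC[C@@H](N)C2)cc(=O)n(Cc2ccc(OC)c(OC)c2)c1=O` gives 1.55 in a physicochemical assay for lipophilicity; on this read-out higher numbers stand for higher lipophilicity and lower numbers for lower lipophilicity. Compound 2 `CC#CCn1c(N2CCC[C@@H](N)C2)cc(=O)n(Cc2cc(Br)c(OC)c(OC)c2)c1=O` gives 2.38 in this assay, and compound 3 `CC#CCn1c(N2CCC[C@@H](N)C2)cc(=O)n(Cc2cc(OC)c(OC)c(Br)c2Br)c1=O` gives 3.21. Compound 3 stands highest of the three numbers; its nearest neighbour is compound 2, and compound 1 lies furthest below it. The two measured steps are a number 0.83 log units higher from compound 1 to compound 2 (beyond the scatter) and a number 0.83 log units higher from compound 2 to compound 3 (beyond the scatter), both the same kind of change, and both beyond the scatter.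

Compound 4 `CC#CCn1c(N2CCC[C@@H](N)C2)cc(=O)n(Cc2c(Br)c(Br)c(OC)c(OC)c2Br)c1=O` carries that same kind of change once more: bromo in place of hydrogen on an aromatic carbon. Both earlier steps bear on it: each was bromo in place of hydrogen on an aromatic carbon, and each rose by the same modest amount. A further rise of similar size, beyond the scatter, is expected for compound 4, namely a number 0.74 log units higher from compound 3 to compound 4 (beyond the scatter). Compound 4 is accordingly estimated to give 3.95 in this assay, within a range of 3.5 to 4.4.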

Compound 4, partition coefficient: 4.04
Compound 4: the middle estimate sits 0.09 log units below what was measured; the measured number falls inside the stated range.
By their numbers in this assay, from the lowest: compound 1; then compound 2; then compound 3; then compound 4.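

Compound 4 places bromo on an aromatic carbon ortho to a large group, ortho to a methoxy group and para to a bromo group, and in this assay the series still gives a number 0.83 log units higher from compound 3 to compound 4 (beyond the scatter). That step matches both a number 0.83 log units higher from compound 1 to compound 2 (beyond the scatter) and a number 0.83 log units higher from compound 2 to compound 3 (beyond the scatter), so across these three compounds the rise does not shrink as bromo groups accumulate on the ring, even at this position. No supporting measurement is available to explain why the step size stays constant.

The compounds shown leave open how the number would respond to chloro, an amine or a carboxylic acid in place of bromo at this aromatic carbon. They also leave open whether a single bromo at this position, without the other two bromo groups, would give a step of the same size.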